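Working notes: from compound 2 to compound 3

The compounds below may be only part of what the source reports. "The series", "measured", "known", "first", "only" and "open" are said of these compounds alone.

In a functional assay on HT-29 cells (Homo sapiens) for antiproliferative activity, read by sulforhodamine B assay, with a stated time of 72 h (on this read-out higher numbers stand for weaker inhibition and lower numbers for stronger inhibition), compound 1 (`CCN1C(=O)CS/C1=N/Nc1nncc2ccccc12`) gives 58 nM. Among the compounds with values here, compound 2 (`C(=C/c1ccccc1)\C(=N\Nc1nncc2ccccc12)c1ccccc1`) gives 1.1 nM, the lower of the two numbers so far, and its gap to compound 1 lies beyond the scatter. These two compounds differ in more than one place, so the gap cannot be assigned to any single change.

Compound 3 (`Clc1ccc(C(/C=C/c2ccccc2)=N\Nc2nncc3ccccc23)cc1`) has not yet been measured in this assay. Relative to compound 2 it has chloro in place of hydrogen on an aromatic carbon, para to a large group, so that phenyl becomes 4-chlorophenyl: chloro in place of hydrogen on an aromatic carbon. Within the data shown here, no measured pair shows this change, so the expectation rests only on compound 2 at 1.1 nM. A small shift towards a higher number is expected, most likely not beyond the scatter. The estimated move is a 1.4-fold higher number from compound 2 to compound 3 (0.13 log units; within the scatter). For compound 3 the expected value is 1.5 nM, with an estimated range of 0.3 nM to 7 nM.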

Compound 3, half-maximal inhibitory concentration: 2.3 nM
For compound 3 the middle estimate is 1.5-fold (0.19 log units) below the measured one; measured number inside the range.
By their numbers in this assay, from the lowest: compound 2; then compound 3; then compound 1.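

The series now has its first step confined to one place: in this assay, chloro in place of hydrogen on an aromatic carbon, para to a large group, gives a 2.1-fold higher number from compound 2 to compound 3 (0.32 log units; beyond the scatter), a modest move that is nonetheless printed as beyond the scatter. This shows that the position can carry a chlorine atom with the number staying low, as compound 3 gives 2.3 nM, while the direction of the step is towards weaker inhibition rather than stronger. No data at hand bear on why the number moves with this change.

Within the data shown here, with only one step at this position, it is open whether the change from phenyl to 4-chlorophenyl reflects a wider trend, or whether it is specific to chloro. On these data alone, a fluoro, methoxy or amine group at the same place, or a carboxylic acid there, could show whether the number rises further or returns towards that of compound 2, and the same chloro change on the second phenyl of the shared core also remains open.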